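A few compounds are considered here, and "the series" means these few. Any claim that something is new, unique, unknown or untested is made for them only; others in the source may bear on it.

Of the compounds shown here, three of one shared core have been measured in an assay on isolated protein for binding affinity to vitamin D3 receptor (Homo sapiens), read by fluorescence polarization, tested at 1 uM; on this read-out higher numbers stand for more inhibition at the one concentration tested (going by the name of the read-out) and lower numbers for less inhibition. Compound 1 `CCCC(O)(C#Cc1ccc(C(CC)(CC)C2=CCC(C(=O)NCCN(CC)CC)N2CC)cc1C)CCC` gives 52.1%. Compound 2 `CCN(CC)CCNC(=O)C1CC=C(C(CC)(CC)c2ccc(C#CC(O)C3CCCC3)c(C)c2)N1CC` gives 47.9%, and compound 3 `CCN(CC)CCNC(=O)C1CC=C(C(CC)(CC)c2ccc(C#CC(O)C3CCCCC3)c(C)c2)N1CC` gives 45.6%. Among these three, compound 3 is lowest on the numbers shown, with compound 2 nearest and compound 1 furthest, but both gaps lie within the scatter. The measured steps are small: a number 4.2 percentage points lower from compound 1 to compound 2 (within the scatter), a number 6.5 percentage points lower from compound 1 to compound 3 (within the scatter) and a number 2.3 percentage points lower from compound 2 to compound 3 (within the scatter), every one of them within the scatter.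

Compound 4 `CCN(CC)CCNC(=O)C1CC=C(C(CC)(CC)c2ccc(/C=C/C(C)(O)CC)c(C)c2)N1CC` is not yet measured in this assay. It differs from compound 3 in that (a group of 7 heavy atoms (6 carbon, 1 oxygen; no ring) in place of a group of 10 heavy atoms (9 carbon, 1 oxygen; one six-membered non-aromatic ring of carbon only), on an aromatic carbon). All three measured steps bear on the same position, since each exchanges the group on the triple-bonded carbon, and none of them moved the read-out beyond the scatter. None of them, however, replaced the triple bond with a double bond, so the step to compound 4 goes beyond what the measured steps cover. On that footing a step of a number 0.4 percentage points higher from compound 3 to compound 4 (within the scatter) is expected, that is, no movement beyond the scatter, with a wider range to allow for the untested change. Compound 4 is therefore estimated to give 46% in this assay, between 28% and 62%.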

Compound 4, a percentage reported as inhibition, at one concentration (the size of the read-out at that concentration, not a potency): 68.9%
Compound 4: the middle estimate sits 22.9 percentage points below what was measured, outside the stated range (above it).
By their numbers in this assay, from the lowest: compounds 3, 2 and 1 (each within the scatter of the next); then compound 4.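

The position on the aromatic carbon, which had stayed flat through every exchange of the group on the triple-bonded carbon, proves responsive in this assay once the triple bond gives way to a double bond and the end group changes with it: the read-out shows a number 23.3 percentage points higher from compound 3 to compound 4 (beyond the scatter), a number 21 percentage points higher from compound 2 to compound 4 (beyond the scatter) and a number 16.8 percentage points higher from compound 1 to compound 4 (beyond the scatter). Losing the ring cannot by itself account for this, since compound 1 also carries a group with no ring, yet it lies within the scatter of the ring-bearing compound 2 and compound 3 and still falls beyond the scatter of compound 4. No measurement is at hand that explains the rise.

Each of these steps changes the bond and the end group together, so the compounds shown leave open which of the two carries the rise, a question that the group of compound 4 on a triple bond, or a cyclohexyl group on a double bond, would settle. Also open, from the compounds shown here alone, is how a saturated two-carbon link or a cis double bond would read here, and whether the rise at this single concentration would hold as a difference in potency.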